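The source may report more compounds than this note shows. Statements on the series, on what has been measured and on what is new or still open speak of the compounds shown alone.

Working notes on the series.

Among the measured compounds shown here, in a functional assay on HT-29 cells (Homo sapiens) for cytotoxicity, read by MTT assay, with a stated time of 72 h (a lower number here means a stronger inhibitor, a higher number a weaker inhibitor), compound 3 `CN(C)CCn1cnnc1-c1cc(Oc2ccc(NC(=O)N/N=C/c3ccccc3)cc2F)ccn1` gives 1120 nM, the second highest of the three numbers so far. Compound 2 `CN(C)CCn1cnnc1-c1cc(Oc2ccc(NC(=O)N/N=C/c3ccccc3O[N+](=O)[O-])cc2F)ccn1` gives 950 nM and compound 1 `COc1ccc(/C=N/NC(=O)Nc2ccc(Oc3ccnc(-c4nncn4CCN(C)C)c3)c(F)c2)c(OC)c1OC` gives 3970 nM. The two measured steps that reach compound 3 both change the ring on the carbon double-bonded to nitrogen: a 3.5-fold lower number from compound 1 to compound 3 (0.55 log units; beyond the scatter), and a 1.2-fold higher number from compound 2 to compound 3 (0.07 log units; within the scatter). The third step, a 4.2-fold lower number from compound 1 to compound 2 (0.62 log units; beyond the scatter), has the same carbon as its site. So far the bare phenyl and the nitrooxy-bearing phenyl sit close together, while the trimethoxy-bearing ring gives the higher number.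

Compound 4 `CN(C)CCn1cnnc1-c1cc(Oc2ccc(NC(=O)N/N=C/c3c(O)ccc4ccccc34)cc2F)ccn1` carries the change (2-hydroxynaphthalen-1-yl in place of phenyl on a carbon with a double bond to nitrogen). For the measured compounds named here, no measured step covers a second fused ring or a hydroxy group at this position; the only guidance is that decorating the ring with three methoxy groups raised the number, whereas one nitrooxy left it within scatter. On that basis the step from compound 3 to compound 4 in this assay is expected to be small, a 1.2-fold higher number from compound 3 to compound 4 (0.06 log units; within the scatter), with no confident direction. The estimate for compound 4 in this assay is therefore 1300 nM, with a range from 500 nM to 3500 nM.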

Compound 4, half-maximal inhibitory concentration: 670 nM
The estimate for compound 4 lay 1.9-fold (0.29 log units) above the measured number; measured number inside the range.
By their numbers in this assay, from the lowest: compounds 4, 2 and 3 (each within the scatter of the next); then compound 1.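

In this assay, the position on the carbon with a double bond to nitrogen accepts 2-hydroxynaphthalen-1-yl, with its second aromatic ring and its hydroxy group, and the number stays within the scatter of both the bare phenyl (a 1.7-fold lower number from compound 3 to compound 4 (0.22 log units; within the scatter)) and the 2-(nitrooxy)phenyl (a 1.4-fold lower number from compound 2 to compound 4 (0.15 log units; within the scatter)). Compounds 2, 3 and 4 therefore form one group that these data cannot separate, and a larger ring system at this carbon does not by itself go with a higher number, while compound 1, with 2,3,4-trimethoxyphenyl, stands apart (a 5.9-fold lower number from compound 1 to compound 4 (0.77 log units; beyond the scatter)). Nothing available here explains why the trimethoxy-bearing ring differs from the other three groups.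

The compounds shown leave open whether the hydroxy group and the second fused ring each fit this position on their own, which a plain naphthalen-1-yl and a 2-hydroxyphenyl on this carbon would separate. Going by these compounds, it also remains open whether a single methoxy group is enough to give a number like that of compound 1, or whether an amine or a carboxylic acid on the ring would stay within this group.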